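Swapping dimethylamino for nitro in a cell toxicity test

The source may report more compounds than this note shows. Statements on the series, on what has been measured and on what is new or still open speak of the compounds shown alone.

Compound 1 `O=C1[C@H]2N=NN(Cc3nc(-c4ccc(Br)cc4)no3)[C@H]2C(=O)N1c1ccccc1` and compound 2 `CN(C)c1ccc(-c2noc(CN3N=N[C@@H]4C(=O)N(c5ccccc5)C(=O)[C@@H]43)n2)cc1` share one core and differ in a single group. In an ADME assay on L6 cells (Rattus norvegicus) for cytotoxicity, read by resazurin assay, with a stated time of 72 h (a higher number here means a weaker inhibitor, a lower number a stronger inhibitor), compound 1 gives 58.6 ug/mL as its value. For compound 2 the reading (> 100 ug/mL) is a limit and not a number.

Compound 3 `O=C1[C@H]2N=NN(Cc3nc(-c4ccc([N+](=O)[O-])cc4)no3)[C@H]2C(=O)N1c1ccccc1` keeps the same core and carries nitro in place of dimethylamino on an aromatic carbon. Among the compounds with values here, one measured step bears on this place: an at least 1.7-fold higher number from compound 1 to compound 2 (0.23 log units; that floor lies within the scatter) with dimethylamino in place of bromo, and that floor lies within the scatter. It therefore fixes no firm size or direction. Within the data shown here, the only true number to lean on is that of compound 1 (58.6 ug/mL), so a modest move to lower numbers is expected. The estimated change is an at least 1.6-fold lower number from compound 2 to compound 3 (0.22 log units; that floor lies within the scatter) in this assay and it may not pass the scatter. For compound 3 the expected value is 60 ug/mL within an estimated range of 22 ug/mL to 100 ug/mL in this assay.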

Compound 3, half-maximal inhibitory concentration: > 100 ug/mL
Compound 3 gave a limit, no number; the forecaster's own chance of this, stated with the estimate: 25%; middle value at least 1.6-fold (0.22 log units) from the limit.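

At this position on the aromatic ring, compound 3 shows that nitro, like dimethylamino, gives a limit and not a number in this assay. Replacing bromo with nitro gives an at least 1.7-fold higher number from compound 1 to compound 3 (0.23 log units; that floor lies within the scatter), so only a floor is known, and it does not establish a real change. The step between compound 2 and compound 3 cannot be read, because both readings stop at the same limit: the limit of > 100 ug/mL in this assay, at which 2 of the 3 values shown sit.

On these data alone, the true values of compound 2 and compound 3 stay open, and with them whether dimethylamino and nitro differ at all in this assay. Also open, as far as these compounds go, is how a carboxylic acid, a primary amine or a longer alkyl chain at this position would read, and whether any group here would give a clearly lower number than compound 1, which gives 58.6 ug/mL.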